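The compounds below may be only part of what the source reports. "The series", "measured", "known", "first", "only" and "open" are said of these compounds alone.

The series consists of three measured compounds and one that has not been measured. Compound 1 `CC(=O)O[C@H]1CC[C@@]2(CO2)[C@@H]2[C@H](OC(C)=O)[C@]3(O)[C@@H](C)C(=O)O[C@H]3[C@@H]3O[C@]3(C)CC[C@H](OC(C)=O)[C@@]12C` gives 7.66% in a functional assay on cells (Neutrophil, Homo sapiens) for inhibition, read by colorimetric assay, tested at 10 ug/mL; a higher number here means more inhibition at the concentration tested (going by the name of the read-out), a lower number less inhibition. Compound 2 `CC(=O)O[C@H]1CC/C(C)=C\[C@@H]2OC(=O)[C@H](C)[C@@]2(O)[C@@H](OC(C)=O)[C@H]2[C@]3(CC[C@H](OC(C)=O)[C@]12C)CO3` gives 13.9% in this assay. Compound 3 `CC(=O)O[C@H]1CC[C@]2(CO2)[C@@H]2[C@H](OC(C)=O)[C@]3(O)[C@@H](C)C(=O)O[C@H]3[C@@H](O)[C@](C)(O)CC[C@H](OC(C)=O)[C@@]12C` gives 5.55% in this assay.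

Compound 2 carries the highest of the three numbers, but the gap to compound 1 lies within the scatter, as does the gap to compound 3, so none of the three can be set apart from the others on these numbers alone; all three sit in the low range of inhibition at the tested concentration.

The step under consideration runs from compound 2 to compound 4 `CC(=O)O[C@H]1CC/C(C)=C\[C@@H]2OC(=O)[C@H](C)[C@@]2(O)[C@@H](OC(C)=O)[C@H]2[C@@]3(CC[C@H](OC(C)=O)[C@]12C)CO3`. The difference between them is as follows: the two compounds have the same atoms and bonds and differ only in configuration as drawn: 1 of 10 stereo elements differ; a stereocentre at a saturated ring carbon is drawn R in compound 2 and S in compound 4. For the measured compounds named here, no step between measured compounds is available for comparison, and the measured compounds give no indication of how a change of configuration at a single saturated ring carbon moves the read-out.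

Given that all three measured values lie within the scatter of each other, compound 4 is expected to land in the same low range, with a step from compound 2 that is expected to be a number 2.9 percentage points lower from compound 2 to compound 4 (within the scatter), that is, none beyond the scatter. Compound 4 is therefore estimated at 11%, with a range from 2% to 24%.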

Compound 4, a percentage reported as inhibition, at one concentration (the size of the read-out at that concentration, not a potency): 22.6%
Beside the measured number, compound 4's estimate is 11.6 percentage points below it; measured number inside the range.
By their numbers in this assay, from the lowest: compounds 3, 1, 2 and 4 (each within the scatter of the next, the first and the last beyond it).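

In this assay, for the compounds shown here, this inversion of a stereocentre at a saturated ring carbon, drawn R in one compound and S in the other, gives a number 8.7 percentage points higher from compound 2 to compound 4 (within the scatter), the first step that can be read at a single place. At this stereocentre, then, a change of configuration alone does not move the read-out beyond the usual scatter, so no dependence of inhibition on this centre can be claimed at the tested concentration. The comparison is structurally clean, with nothing entering and nothing leaving, and the step can be attached to this one stereocentre: the fact that compounds 2 and 4 differ only in the configuration as drawn.

The compounds shown leave open whether this stereocentre would matter at other concentrations, since a reading at one concentration is not a potency, and whether inverting any of the other stereo elements would do more than this one. They also leave open whether a change of a different kind, such as an amine or a carboxylic acid on the shared core, would shift the read-out beyond the scatter.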